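A few compounds are considered here, and "the series" means these few. Any claim that something is new, unique, unknown or untested is made for them only; others in the source may bear on it.

Compound 1 `CCc1ccc(NC(=O)Nc2cc(C)nc3ccccc23)cc1`: > 25000 nM (a limit)
Compound 2 `Cc1cc(NC(=O)Nc2ccc(SC(F)(F)F)cc2)c2ccccc2n1`: > 25000 nM (a limit)

In an ADME assay on BJ cells (Homo sapiens) for cytotoxicity, with a stated time of 72 h (a lower number here means that less compound is needed, a higher number that more compound is needed for the effect), compound 2 has no exact number and stands only at a limit, > 25000 nM. Compound 1 also gives only a limit, > 25000 nM. Neither compound can therefore be ranked against the other.

Compound 3 `Cc1cc(NC(=O)Nc2ccc(Cl)cc2)c2ccccc2n1` keeps the shared core of compound 2 but has chloro in place of (trifluoromethyl)sulfanyl on an aromatic carbon, para to a large group: chloro in place of (trifluoromethyl)sulfanyl on an aromatic carbon.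

For the measured compounds named here, one measured step bears on this change, as it alters the same place: a step that the two limits leave unreadable from compound 1 to compound 2. Its size cannot be read, and the evidence is simply (the limit of > 25000 nM in this assay, at which 2 of the 2 values shown sit). So the data show no measured effect of changing this group, only that neither group brought a value inside the measurable range.

Compound 2 sits at > 25000 nM, so the most reasonable expectation is that compound 3 stays at or near this limit, with no clear direction of change. The expected change is a number no higher from compound 2 to compound 3 (the limit leaves the size open), which is no step beyond the usual scatter. For compound 3 the estimated value is 25000 nM, with an expected range of 12000 nM to 50000 nM.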

Compound 3, half-maximal effective concentration: > 25000 nM
Compound 3: only a limit was reported; the forecaster's own chance of this, stated with the estimate: 80%; the middle value lies on the limit itself.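

In this assay compound 3 gives only a limit, > 25000 nM. No step among compound 1, compound 2 and compound 3 can be read, as all three stand at a limit: the limit of > 25000 nM in this assay, at which 3 of the 3 values shown sit.

The compounds shown leave open whether ethyl, (trifluoromethyl)sulfanyl and chloro differ at all in this assay, and what exact value each compound would have.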